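Cytotoxicity notes on an aryloxy-quinoline-amine series

The source may hold more compounds than are shown below. What is called first, only, known or untested is meant among the compounds shown, and "the series" means these compounds.

Measured so far:
compound 1, `COc1ccc(F)cc1CNCCCNc1ccnc2cc(Oc3ccc(F)cc3)ccc12`: 6600 nM
compound 2, `COc1ccc(Oc2ccc3c(NCCCNCc4cccc(OC)c4O)ccnc3c2)cc1`: 5500 nM
compound 3, `COc1cccc(CNCCCNc2ccnc3cc(Oc4ccc(F)cc4)ccc23)c1O`: 11000 nM

In an ADME assay on HepG2 cells (Homo sapiens) for cytotoxicity, read by luminescence, CellTiter-Glo and ATP content, with a stated time of 72 h (a higher number here means that more compound is needed for the effect, a lower number that less compound is needed), compound 1 stands second highest of the three numbers; compound 2 is nearest and compound 3 furthest, and both gaps are within the scatter. The two measured steps are a 1.7-fold higher number from compound 1 to compound 3 (0.22 log units; within the scatter) and a 2.0-fold higher number from compound 2 to compound 3 (0.30 log units; within the scatter), neither beyond the scatter.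

Compound 4, `COc1ccc(F)cc1CNCCCNc1ccnc2cc(Oc3ccccc3OC)ccc12`, differs from compound 1 at the aryloxy group: 2-methoxyphenyl in place of 4-fluorophenyl on an oxygen on an aromatic ring. The step from compound 2 to compound 3 is the only one that touches the phenoxy ring, and it exchanges methoxy and fluoro there; its size was a 2.0-fold higher number from compound 2 to compound 3 (0.30 log units; within the scatter). Read in the opposite sense, that suggests a small move toward a lower number, but nothing that would clear the scatter. The step from compound 1 to compound 3 concerns the other end of the molecule and says little here. Compound 4 is therefore expected to give 5000 nM in this assay, within 2500 nM to 12000 nM, which means an expected step of a 1.3-fold lower number from compound 1 to compound 4 (0.12 log units; within the scatter).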

Compound 4, half-maximal effective concentration: 6400 nM
For compound 4 the middle estimate is 1.3-fold (0.11 log units) below the measured one, and the stated range covers the measured number.
By their numbers in this assay, from the lowest: compounds 2, 4, 1 and 3 (each within the scatter of the next).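

In this assay, replacing 4-fluorophenyl with 2-methoxyphenyl on the oxygen, with the 5-fluoro-2-methoxyphenyl end of compound 1 held fixed, leaves the number unchanged within the scatter (a 1.0-fold lower number from compound 1 to compound 4 (0.01 log units; within the scatter)). The earlier phenoxy evidence rested on a single exchange of methoxy and fluoro on an aromatic carbon, in the 2-hydroxy-3-methoxyphenyl setting (a 2.0-fold higher number from compound 2 to compound 3 (0.30 log units; within the scatter)), whereas this step shows that a different aryl group is also accommodated in the 5-fluoro-2-methoxyphenyl setting without a change beyond the scatter. No measured evidence is available to explain this result.

From the compounds shown here alone, whether any group on this oxygen can shift the number beyond the scatter remains open. A carboxylic acid or a dimethylamino group on the phenyl ring would test this, as would a pyridyl ring in place of the phenyl ring.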